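Removing the lactam arm from a weak brominated catechol series

The source may hold more compounds than are shown below. What is called first, only, known or untested is meant among the compounds shown, and "the series" means these compounds.

Measured so far:
- compound 1, `O=C1CCCN1Cc1c(Br)c(O)c(O)c(Br)c1Br`: 18500 nM
- compound 2, `COCc1c(Br)c(O)c(O)c(Br)c1Cc1c(Br)c(O)c(O)c(Br)c1Br`: 10500 nM

Two compounds have numbers in a functional assay; a higher number here means a weaker inhibitor, a lower number a stronger inhibitor. Compound 1 gives 18500 nM, the higher of the two. Compound 2 gives 10500 nM, a difference from compound 1 that lies within the usual scatter, so the two compounds cannot be ordered against each other on this evidence. Both sit in the weak range of this assay.

Compound 3, `Cc1c(Br)c(O)c(O)c(Br)c1Br`, has not been measured. It differs from compound 1 in one place: hydrogen in place of 2-oxopyrrolidin-1-yl on a saturated chain carbon bound to an aromatic carbon. The saturated chain carbon bound to an aromatic carbon is left carrying hydrogen only, while the shared core is unchanged.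

Among the measured compounds shown here, no step between two measured compounds is available to calibrate what such a removal does. Both measured compounds carry substantial groups on the core and both are weak, which gives no sign that bulk at this position helps or hurts. The expectation is therefore a step of about the size of the scatter, with a slight lean toward a higher number, expressed as a 1.4-fold higher number from compound 1 to compound 3 (0.13 log units; within the scatter). Compound 3 is estimated at 25000 nM, with a range from 8000 nM to 80000 nM.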

Compound 3, half-maximal inhibitory concentration: 14000 nM
Compound 3: the middle estimate sits 1.8-fold (0.25 log units) above what was measured; the range from low to high includes it.
By their numbers in this assay, from the lowest: compounds 2, 3 and 1 (each within the scatter of the next).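

In this assay, hydrogen in place of 2-oxopyrrolidin-1-yl on a saturated chain carbon bound to an aromatic carbon gives a 1.3-fold lower number from compound 1 to compound 3 (0.12 log units; within the scatter), the first step read at this position. The change takes away 6 heavy atoms, a five-membered non-aromatic ring and a hydrogen-bond acceptor, yet compound 3 cannot be told apart from compound 1 in this assay, so the 2-oxopyrrolidin-1-yl group is not required for the weak activity of compound 1. No measurement available here gives a reason for this outcome.

Still open, from the compounds shown here alone, is whether any other group on this saturated chain carbon, such as an amine, a carboxylic acid or a longer chain ending in either, would give a step beyond the scatter in this assay. Also open, going by these compounds, is what the shared core itself contributes, for example whether chloro in place of bromo or methoxy in place of hydroxy would shift the number in either direction.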